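Chloro to Cyano Swap Checked for Inhibition in HUVEC Cells

This account rests on a few compounds, and the source may have more. Where it says the series, first, only, none or still open, it means among the compounds named here.

Of the compounds shown here, three have been measured in an ADME assay on HUVEC cells (Homo sapiens) for inhibition, read by CCK-8 assay, with a stated time of 24 h, in the presence of a further agent that is not named here; on this read-out higher numbers stand for weaker inhibition and lower numbers for stronger inhibition. Compound 1 `O=C1Nc2ccccc2/C1=C/c1ccc(-c2cn(-c3ccccc3Cl)nn2)cc1` gives in this assay a value that is a limit of the assay, > 20000 nM. Compound 2 `N#Cc1ccccc1-n1cc(-c2ccc(/C=C3\C(=O)Nc4ccccc43)cc2)nn1` gives in this assay 19700 nM. Compound 3 `O=C1Nc2ccc(F)cc2/C1=C/c1ccc(-c2cn(-c3cccc(Cl)c3)nn2)cc1` gives in this assay 19400 nM. Compound 2 differs from compound 1 by cyano in place of chloro on an aromatic carbon; this change gave an at least 1.0-fold lower number from compound 1 to compound 2 (0.00 log units; that floor lies within the scatter), a floor that rests on (the limit of > 20000 nM in this assay, at which 1 of the 3 values shown sits). How the core of compound 1 and the core of compound 3 differ is not broken down here. Compound 4 `N#Cc1cccc(-n2cc(-c3ccc(/C=C4\C(=O)Nc5ccc(F)cc54)cc3)nn2)c1` has not yet been measured; it differs from compound 3 by cyano in place of chloro on an aromatic carbon. This is the same kind of change as that from compound 1 to compound 2, but the place differs: in the earlier pair the group sits ortho to a large group, in the new pair meta to a large group. Because the earlier step of an at least 1.0-fold lower number from compound 1 to compound 2 (0.00 log units; that floor lies within the scatter) lies within the scatter, the step from compound 3 to compound 4 in this assay is expected to be a 1.0-fold higher number from compound 3 to compound 4 (0.00 log units; within the scatter). Compound 4 is estimated at 19500 nM, with a likely range from 10000 nM to 40000 nM.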

Compound 4, half-maximal inhibitory concentration: > 20000 nM
Compound 4: no number, only a limit (the forecaster's own chance of this, stated with the estimate: 50%); middle value at least 1.0-fold (0.01 log units) away from the limit.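

Carried to the core of compound 3, on an aromatic carbon meta to a large group, cyano in place of chloro gave in this assay an at least 1.0-fold higher number from compound 3 to compound 4 (0.01 log units; that floor lies within the scatter). Set beside the earlier step on the core of compound 1, the result stays undecided: the same change on two cores in this assay, an at least 1.0-fold lower number (0.00 log units; that floor lies within the scatter) from compound 1 to compound 2 and an at least 1.0-fold higher number (0.01 log units; that floor lies within the scatter) from compound 3 to compound 4; the limit leaves it open whether they differ. Neither step on its own shows a change beyond the scatter, but both rest on a limit, so the data do not show that the swap is without effect on either core or that it carries over unchanged from one core to the other: the limit of > 20000 nM in this assay, at which 2 of the 4 values shown sit.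

The compounds shown leave open how an amine or a carboxylic acid in place of chloro or cyano on that aromatic carbon would read in this assay. They also leave open how large the swap itself would be on a core whose values fall clear of the limit, where both ends of the step could be read as numbers.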